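A few compounds are considered here, and "the series" means these few. Any claim that something is new, unique, unknown or untested is made for them only; others in the source may bear on it.

Measured so far in a functional assay on MDA-MB-231 cells (Homo sapiens) for antiproliferative activity, read by MTT assay, with a stated time of 24 h; a lower number here means a stronger inhibitor, a higher number a weaker inhibitor

Compound 1 `O=C(O)CC(NS(=O)(=O)c1cc(F)cc(F)c1)c1ccccc1F` gives 73500 nM
Compound 2 `O=C(O)CC(NS(=O)(=O)c1ccccc1)c1ccc(Cl)cc1Cl` gives 57800 nM
Compound 3 `N#Cc1ccc(S(=O)(=O)NC(CC(=O)O)c2ccc(Cl)cc2Cl)cc1` gives 12600 nM

Compound 3 has the lowest number of the three, and its gaps to compound 1 and compound 2 both lie beyond the usual scatter. The next compound, compound 4 `O=C(O)CC(NS(=O)(=O)c1cc(F)cc(F)c1)c1ccc(Cl)cc1Cl`, keeps the core of compound 3 and changes one group: 3,5-difluorophenyl in place of 4-cyanophenyl on a sulfonyl sulfur.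

Among the compounds with values here, only one measured step bears on this change. Compound 4 gives up the nitrile that came with a 4.6-fold lower number from compound 2 to compound 3 (0.66 log units; beyond the scatter) so part of that modest gain is expected to be lost. Going by these compounds, what the two fluorines bring to this core is unknown. Compound 1 also carries 3,5-difluorophenyl, but it differs from compound 4 elsewhere too, so it offers only a loose guide. Compound 4 is therefore expected to fall between compound 3 and compound 2, probably nearer compound 2. In this assay the expected change is a 2.4-fold higher number from compound 3 to compound 4 (0.38 log units; beyond the scatter) (a modest move toward a weaker inhibitor). Compound 4 is estimated at 30000 nM with an expected range from 11000 nM to 75000 nM around that figure.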

Compound 4, half-maximal inhibitory concentration: 35700 nM
Compound 4: the middle estimate sits 1.2-fold (0.08 log units) below what was measured; the measured number falls inside the stated range.
By their numbers in this assay, from the lowest: compound 3; then compounds 4, 2 and 1 (each within the scatter of the next, the first and the last beyond it).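

In this assay, a 2.8-fold higher number from compound 3 to compound 4 (0.45 log units; beyond the scatter) comes with 3,5-difluorophenyl in place of 4-cyanophenyl on the sulfonyl sulfur, so on this core the two fluorines do not match what the nitrile-bearing ring gives. Against plain phenyl in the same place, a 1.6-fold lower number from compound 2 to compound 4 (0.21 log units; within the scatter) stays inside the usual noise of the measurement, so 3,5-difluorophenyl cannot be told apart from phenyl here, and of these three groups on the sulfonyl sulfur only 4-cyanophenyl stands out. Within the data shown here, the other end of the molecule counts too: a 2.1-fold lower number from compound 1 to compound 4 (0.31 log units; beyond the scatter) goes with 2,4-dichlorophenyl in place of 2-fluorophenyl on the saturated chain carbon, which is the only step read at that place and a modest one.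

Nothing shown here explains why these groups differ and the numbers record only the size of each step. Going by these compounds, it remains open whether another group in place of the nitrile on the sulfonyl-bound ring, such as a methoxy or an amine, would do as well, and whether an amide could stand in for the carboxylic acid.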